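Methoxy in place of fluoro: from compound 1 to compound 4

The compounds below may be only part of what the source reports. "The series", "measured", "known", "first", "only" and "open" are said of these compounds alone.

Measured so far:
compound 1 `Nc1cc(N)c2nc(-c3ccccc3)c(Sc3ccc(F)cc3)nc2c1` — 60300 nM
compound 2 `COc1cc(CNc2nc3cc(N)cc(N)c3nc2-c2ccccc2)cc(OC)c1OC` — 27500 nM
compound 3 `CCOC(=O)[C@H](CCC(=O)O)NC(=O)c1ccc(Oc2nc3cc(N)cc(N)c3nc2-c2ccccc2)cc1` — a limit, < 100000 nM

In a functional assay on UACC-257 cells (Homo sapiens) for inhibition, read by sulforhodamine B assay, with a stated time of 48 h (a higher number here means that more compound is tolerated, a lower number that less compound is tolerated), compound 1 gives 60300 nM, the highest of the two numbers; compound 2 gives 27500 nM, a gap beyond the scatter. For compound 3 only a limit is recorded, < 100000 nM (the limit of < 100000 nM in this assay, at which 1 of the 3 values shown sits).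

Compound 4 `COc1ccc(Sc2nc3cc(N)cc(N)c3nc2-c2ccccc2)cc1` differs from compound 1 by methoxy in place of fluoro on an aromatic carbon. Within the data shown here, no step between measured compounds covers this change, so the expectation rests on compound 1 alone. The expected step of a 1.2-fold lower number from compound 1 to compound 4 (0.08 log units; within the scatter) is small, within the scatter, with no clear direction. Compound 4 is thus expected near 50000 nM, in a range from 20000 nM to 120000 nM.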

Compound 4, concentration lethal to 50% of the cells: < 100000 nM
Compound 4: a limit, no number; the forecaster's own chance of this, stated with the estimate: 20%; the middle value is on the limit's open side.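

For compound 4, < 100000 nM is a limit and not a number, so the step from compound 1 to compound 4 cannot be read. The compounds shown leave open whether methoxy in place of fluoro shifts the value in this assay at all.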